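Extending the side chain by two carbons

The source may hold more compounds than are shown below. What is called first, only, known or untested is meant among the compounds shown, and "the series" means these compounds.

Three compounds share one core and differ only in the chain attached to it. Compound 1 `O=c1cc(Cn2cc(CCO)nn2)c2ccc(O)cc2o1` and compound 2 `O=c1cc(Cn2cc(CCCCO)nn2)c2ccc(O)cc2o1` carry chains ending in a hydroxy group, while compound 3 `CCCCCCc1cn(Cc2cc(=O)oc3cc(O)ccc23)nn1` carries a plain hydrocarbon chain. In a functional assay on HepG2 cells (Homo sapiens) for inhibition, read by MTT assay, with a stated time of 72 h (a higher number here means a weaker inhibitor, a lower number a stronger inhibitor), compound 1 gives only a limit, > 100000 nM. Compound 2 likewise reaches only a limit, > 100000 nM. For the measured compounds named here, compound 3 is the single compound with an actual number, 61600 nM, so it stands as the one measurable point, the other two sitting at the limit of > 100000 nM in this assay, at which 2 of the 3 values shown sit.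

The step of an at least 1.6-fold lower number from compound 1 to compound 3 (0.21 log units; that floor lies within the scatter) and the step of an at least 1.6-fold lower number from compound 2 to compound 3 (0.21 log units; that floor lies within the scatter) both put butyl or ethyl in place of hydroxy and both read as a lowering, though their floors sit within the scatter. Compound 4 `CCCCCCCCc1cn(Cc2cc(=O)oc3cc(O)ccc23)nn1` takes this further: ethyl in place of hydrogen on a saturated chain carbon, six bonds along the chain from an aromatic carbon. The two measured steps point, if anywhere, toward lower numbers, so a small further lowering, or none beyond the scatter, is expected. Compound 4 is therefore estimated at 40000 nM, between 15000 nM and 100000 nM, which means an expected step of a 1.5-fold lower number from compound 3 to compound 4 (0.19 log units; within the scatter).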

Compound 4, half-maximal inhibitory concentration: 34200 nM
Estimate against measurement, compound 4: 1.2-fold (0.07 log units) above, within the range that was stated.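

In this assay, ethyl in place of hydrogen at this far point on the plain hydrocarbon chain gives a 1.8-fold lower number from compound 3 to compound 4 (0.26 log units; within the scatter), so the two chains cannot be told apart and this lengthening alone shows no clear gain. What is new lies in the comparison with the chains that end in hydroxy: the set now holds an at least 2.9-fold lower number from compound 2 to compound 4 (0.46 log units; beyond the scatter), and also an at least 2.9-fold lower number from compound 1 to compound 4 (0.46 log units; beyond the scatter), the first gaps here that clear the scatter and so the first firm sign that a plain hydrocarbon chain reads differently from a hydroxy-ended one. Whether this gap depends on which hydroxy-ended chain is replaced cannot be settled: the same change on two cores in this assay, an at least 1.6-fold lower number (0.21 log units; that floor lies within the scatter) from compound 1 to compound 3 and an at least 2.9-fold lower number (0.46 log units; beyond the scatter) from compound 2 to compound 4; the limit leaves it open whether they differ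

From the compounds shown here alone, the true size of both gaps stays unknown, as the hydroxy-ended chains give no actual number: the limit of > 100000 nM in this assay, at which 2 of the 4 values shown sit. Also open is whether a longer chain than that of compound 4 would move the number beyond the scatter, and whether an amine or a carboxylic acid at the chain end would read like hydroxy or like the plain chain.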